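Pyridin-3-yl in place of hexylsulfanyl at the varied aromatic carbon

The source may hold more compounds than are shown below. What is called first, only, known or untested is meant among the compounds shown, and "the series" means these compounds.

Compound 1 `CC1CCN(c2cc(C(F)(F)F)ccc2CNC(=O)C(C)c2ccc(NS(C)(=O)=O)c(F)c2)CC1` in an assay on CHO cells for antagonist activity at transient receptor potential cation channel subfamily V member 1 (Homo sapiens), read by FLIPR; on this read-out higher numbers stand for weaker inhibition and lower numbers for stronger inhibition: 0.9 nM
Compound 2 `CCCCSc1cc(C(F)(F)F)ccc1CNC(=O)C(C)c1ccc(NS(C)(=O)=O)c(F)c1`: 1.9 nM
Compound 3 `CCCCCCSc1cc(C(F)(F)F)ccc1CNC(=O)C(C)c1ccc(NS(C)(=O)=O)c(F)c1`: 1.8 nM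

Compound 3 holds the second highest of the three numbers, yet both of its steps stay within the usual scatter: a 2.0-fold higher number from compound 1 to compound 3 (0.30 log units; within the scatter) and a 1.1-fold lower number from compound 2 to compound 3 (0.02 log units; within the scatter). Going by the values given here, only the step of a 2.1-fold higher number from compound 1 to compound 2 (0.32 log units; beyond the scatter) reaches beyond it, and modestly.

Compound 4 `CC(C(=O)NCc1ccc(C(F)(F)F)cc1-c1cccnc1)c1ccc(NS(C)(=O)=O)c(F)c1` differs from compound 3 at one place: pyridin-3-yl in place of hexylsulfanyl on an aromatic carbon. Among the compounds with values here, the steps that bear on this position, from compound 1 and compound 2 to compound 3, were small, and they exchanged a saturated ring for chains; no aromatic ring has yet been tried here. The step of a 1.7-fold higher number from compound 3 to compound 4 (0.22 log units; within the scatter) is therefore expected to be small, with no clear direction beyond the scatter. Compound 4 is estimated at 3 nM, in the range 1 nM to 12 nM.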

Compound 4, inhibition constant: 59.4 nM
The estimate for compound 4 lay 20-fold (1.30 log units) below the measured number, outside the stated range (above it).
By their numbers in this assay, from the lowest: compounds 1, 3 and 2 (each within the scatter of the next, the first and the last beyond it); then compound 4.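

At this position the aromatic pyridin-3-yl ring behaves unlike the saturated ring and the sulfanyl chains, with weaker inhibition in this assay in every comparison: a 33-fold higher number from compound 3 to compound 4 (1.52 log units; beyond the scatter) and a 31-fold higher number from compound 2 to compound 4 (1.50 log units; beyond the scatter) and a 66-fold higher number from compound 1 to compound 4 (1.82 log units; beyond the scatter). Hexylsulfanyl and pyridin-3-yl have matching hydrogen-bond donor and acceptor counts, so those counts do not separate them. No supporting measurement accounts for the loss.

Open, on these data alone, is whether the loss belongs to aromatic rings generally or to this one. Phenyl, pyridin-4-yl and piperidin-3-yl would separate these cases.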